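A few compounds are considered here, and "the series" means these few. Any claim that something is new, unique, unknown or untested is made for them only; others in the source may bear on it.

Of the compounds shown here, three have been measured in a functional assay on HEK293 cells for activation of melanin-concentrating hormone receptor 1 (Homo sapiens), read by inositol phosphate accumulation; on this read-out higher numbers stand for an effect only at larger amounts of compound and lower numbers for an effect already at smaller amounts. Compound 1 `CC(C)(C)c1cc(N)c2cc(NC(=O)/C=C/c3ccc(C(F)(F)F)cc3)ccc2n1` gives 29 nM, the lowest of the three numbers. Compound 3 `CCCc1cc(N)c2cc(NC(=O)c3ccc(-c4ccc(Cl)cc4)cc3)ccc2n1` gives 75 nM, a number beyond the scatter above that of compound 1. Compound 2 `CCCc1cc(NC2CCC2)c2cc(NC(=O)/C=C/c3ccc(C(F)(F)F)cc3)ccc2n1` gives 270 nM, the furthest from compound 1 and also beyond the scatter. None of the three pairs differs in one place only, so no single step can be read off among the measured compounds.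

Compound 4 `Nc1cc(C2CCCCC2)nc2ccc(NC(=O)/C=C/c3ccc(C(F)(F)F)cc3)cc12` is not yet measured. Relative to compound 1 the change is cyclohexyl in place of tert-butyl on an aromatic carbon. The rest of the structure is unchanged. Going by the values given here, no measured pair informs on what this exchange on the shared core does, so the expectation rests on compound 1 alone. A step from compound 1 to compound 4 of a 1.4-fold higher number from compound 1 to compound 4 (0.14 log units; within the scatter) is expected, that is, no step beyond the scatter in either direction, with a wide range to reflect the lack of a precedent. Compound 4 is estimated at 40 nM, between 15 nM and 110 nM.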

Compound 4, half-maximal effective concentration: 96 nM
Compound 4: middle estimate off by 2.4-fold (0.38 log units), on the low side, and the stated range covers the measured number.
By their numbers in this assay, from the lowest: compound 1; then compounds 3 and 4 (each within the scatter of the next); then compound 2.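

In this assay, the aromatic carbon next to the ring nitrogen now has its first comparison in one place: cyclohexyl in place of tert-butyl gives a 3.3-fold higher number from compound 1 to compound 4 (0.52 log units; beyond the scatter). This position is therefore not indifferent to the group it carries, even though neither group has any hydrogen-bond donors or acceptors and both consist of carbon only. Nothing available explains the step.

This single pair does not separate the contribution of the ring from that of the larger number of heavy atoms, so it gives no trend across groups at this position. Still open, on these data alone, is how an isopropyl group, a phenyl ring, a piperidine or an amine at the same carbon would compare with tert-butyl and cyclohexyl on the shared core.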